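Working notes: from compound 2 to compound 4

The source may hold more compounds than are shown below. What is called first, only, known or untested is meant among the compounds shown, and "the series" means these compounds.

Values in a functional assay on HeLa cells (Homo sapiens) for antiproliferative activity, read by MTT assay, with a stated time of 48 h; a higher number here means a weaker inhibitor, a lower number a stronger inhibitor:
Compound 1 `COc1ccc(/C=C/C=C\c2cc(OC)c(OC)c(OC)c2)cc1O`: 62 nM.
Compound 2 `CCOc1cc(-c2ccc3cc[nH]c3c2)cn2c(-c3cc(OC)c(OC)c(OC)c3)nnc12`: 272 nM.
Compound 3 `COc1cc(-c2nnc3c(OC4CN(C(C)(C)C)C4)cc(-c4ccc5[nH]ccc5c4)cn23)cc(OC)c1OC`: > 10000 nM, a limit and not a number.

Of the two actual numbers in this assay, compound 2 holds the higher, 272 nM. Compound 1 sits lower at 62 nM, a gap beyond the scatter. Compound 3 gives only a limit, so it cannot be ranked numerically.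

Compound 4 `CCOc1cc(-c2ccc3c(ccn3C)c2)cn2c(-c3cc(OC)c(OC)c(OC)c3)nnc12` is still to be measured. It differs from compound 2 at one place on the shared core, an aromatic carbon of a six-membered aromatic ring with 1 nitrogen: 1-methyl-1H-indol-5-yl in place of 1H-indol-6-yl (1-methyl-1H-indol-5-yl in place of 1H-indol-6-yl on an aromatic carbon).

For the measured compounds named here, no pair of measured compounds isolates this change, so any expectation is loose. In this assay, a modest move towards a lower number is expected, and no change beyond the scatter remains possible. The expected step is a 2.3-fold lower number from compound 2 to compound 4 (0.36 log units; beyond the scatter). For compound 4 the estimated value is 120 nM, with an expected range of 25 nM to 600 nM.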

Compound 4, half-maximal inhibitory concentration: 210 nM
Beside the measured number, compound 4's estimate is 1.8-fold (0.24 log units) below it, within the range that was stated.
By their numbers in this assay, from the lowest: compound 1; then compounds 4 and 2 (each within the scatter of the next). At a limit, above all of these: compound 3.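

In this assay, there is a 1.3-fold lower number from compound 2 to compound 4 (0.11 log units; within the scatter), so 1-methyl-1H-indol-5-yl in place of 1H-indol-6-yl on this aromatic carbon of the shared core gives no change beyond the scatter. Compound 4 therefore keeps a measured number with 0 hydrogen-bond donors in this group, where the group it replaces has 1, so that donor is not needed for a value in this range. No measured property bears on this step, so nothing can be said about what lies behind it.

Still open, from the compounds shown here alone, is what each part of the swap does alone, the 1-methyl group and the change from 6-yl to 5-yl, since the step carries both together. Also open, going by these compounds, is how this position responds to a different kind of group, such as an open-chain amine or a carboxylic acid, in place of either indolyl group.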